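Shortening the amide side chain in an antiproliferative series

The compounds below may be only part of what the source reports. "The series", "measured", "known", "first", "only" and "open" are said of these compounds alone.

Compound 1: `C[C@@H](c1ccc(NC(=O)N2CC(c3cncc(N)c3)C2)cc1)N1Cc2ccccc2C1=O` — 45 nM
Compound 2: `C[C@H](NC(=O)c1cccc(F)c1)c1ccc(NC(=O)N2CC(c3cncc(N)c3)C2)cc1` — 240 nM
Compound 3: `C[C@H](NC(=O)C1CCOCC1)c1ccc(NC(=O)N2CC(c3cncc(N)c3)C2)cc1` — 500 nM
Compound 4: `CCC(=O)N[C@@H](C)c1ccc(NC(=O)N2CC(c3cncc(N)c3)C2)cc1` — not yet measured

Of the compounds shown here, three sharing one core have been tested in a functional assay on A2780 cells (Homo sapiens) for antiproliferative activity, read by CellTiter-Glo, with a stated time of 72 h; on this read-out lower numbers stand for stronger inhibition and higher numbers for weaker inhibition. Compound 1 gives 45 nM, compound 2 gives 240 nM, and compound 3 gives 500 nM. Compound 3 therefore stands highest of the three, that is, weakest; it is closest to compound 2 and furthest from compound 1. The measured steps are a 5.3-fold higher number from compound 1 to compound 2 (0.73 log units; beyond the scatter), an 11-fold higher number from compound 1 to compound 3 (1.05 log units; beyond the scatter) and a 2.1-fold higher number from compound 2 to compound 3 (0.32 log units; beyond the scatter).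

Compound 4 differs from compound 3 in one place: ethyl in place of oxan-4-yl on a carbonyl carbon. Going by the values given here, the only measured step at this position, a 2.1-fold higher number from compound 2 to compound 3 (0.32 log units; beyond the scatter), shows that swapping the group on the carbonyl carbon moves the number modestly, and compound 3 already carries the weakest of the three groups tried. Nothing measured shows an ethyl at this place, so the direction is uncertain; a further modest rise, or no change beyond the scatter, seems most likely. Compound 4 is therefore estimated at 700 nM, within 250 nM to 2000 nM, a step of a 1.4-fold higher number from compound 3 to compound 4 (0.15 log units; within the scatter) that is expected rather than known.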

Compound 4, half-maximal inhibitory concentration: 770 nM
Compound 4: middle estimate off by 1.1-fold (0.04 log units), on the low side; low and high end bracket the measured number.
By their numbers in this assay, from the lowest: compound 1; then compound 2; then compounds 3 and 4 (each within the scatter of the next).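

In this assay, ethyl on the carbonyl carbon cannot be told apart from oxan-4-yl, with a 1.5-fold higher number from compound 3 to compound 4 (0.19 log units; within the scatter), so at this position the oxan-4-yl ring brings no measurable gain over the small open chain. Ethyl in place of 3-fluorophenyl gives a 3.2-fold higher number from compound 2 to compound 4 (0.51 log units; beyond the scatter), and the propanoylamino side chain in place of the ring-bearing group of compound 1 gives a 17-fold higher number from compound 1 to compound 4 (1.23 log units; beyond the scatter), so among these four compounds, the two with an aromatic ring in the side chain, compound 1 and compound 2, give the lowest numbers. Nothing measured here gives a reason for these steps.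

The compounds shown leave open whether a longer chain such as butyl, or a chain ending in an amine or a carboxylic acid, would stay level with ethyl. They also leave open whether plain phenyl on the carbonyl carbon would match 3-fluorophenyl.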